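Replacing 4-methoxyphenyl with (4-methylphenyl)carbamoyl

The source may hold more compounds than are shown below. What is called first, only, known or untested is meant among the compounds shown, and "the series" means these compounds.

Measured so far in a functional assay on HUVEC cells (Homo sapiens) for inhibition, with stated times of 2 h and 72 h (on this read-out higher numbers stand for weaker inhibition and lower numbers for stronger inhibition), as limits only:
- compound 1 `COc1cc2nccc(Oc3ccc4c(NC(=O)c5cc(Cl)ccn5)nn(C)c4c3)c2cc1OC` gives > 1000 nM as a limit
- compound 2 `COc1ccc(Nc2nn(C)c3cc(Oc4ccnc5cc(OC)c(OC)cc45)ccc23)cc1` gives > 1000 nM as a limit

Compound 2 stands at > 1000 nM in this assay and this is a limit, not a number. The evidence so far is the limit of > 1000 nM in this assay, at which 2 of the 2 values shown sit, and nothing more. Among the measured compounds shown here, the only measured step is a step that the two limits leave unreadable from compound 1 to compound 2 and it gives no size to carry forward. Compound 3 `COc1cc2nccc(Oc3ccc4c(NC(=O)Nc5ccc(C)cc5)nn(C)c4c3)c2cc1OC` carries this change: (4-methylphenyl)carbamoyl in place of 4-methoxyphenyl on a nitrogen on an aromatic ring. In words, (4-methylphenyl)carbamoyl stands in place of 4-methoxyphenyl on a nitrogen on an aromatic ring. With no readable step as a guide, a loosely estimated move towards stronger inhibition is expected, an at least 3.3-fold lower number from compound 2 to compound 3 (0.52 log units; beyond the scatter) in size. Compound 3 is expected at 300 nM with 20 nM to 3000 nM as its estimated range.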

Compound 3, half-maximal inhibitory concentration: > 1000 nM
Compound 3: no number, only a limit; the forecaster's own chance of this, stated with the estimate: 40%; at least 3.3-fold (0.52 log units) between middle value and limit.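

Among the compounds shown here, compound 1, compound 2 and compound 3 each give only a limit, not a number, so no step between them can be read. Going by these compounds, how strongly each compound inhibits, and whether either change shifts that, stays open.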